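The source may report more compounds than this note shows. Statements on the series, on what has been measured and on what is new or still open speak of the compounds shown alone.

Measured compounds:
- compound 1, `CN1C(=O)/C(=C(/S)N(C)c2ccccc2)C(=O)c2cc(Cl)ccc21`: 64%; 64% (2 entries) in a functional assay on the whole organism for inhibition, with Mus musculus as the target, at a dose of 10 mg/kg by the oral route; a higher number here means more inhibition at the dose given (going by the name of the read-out), a lower number less inhibition
- compound 2, `CN1C(=O)/C(=C(/S)N(C)c2ccc(F)c(F)c2)C(=O)c2cc(Cl)ccc21`: 62% in this assay

Compound 1 carries two entries with the same reading, and in this assay compound 1 gives 64%; 64% (2 entries). In this assay, within the data shown here, compound 2 gives 62%, which is the only number recorded for it; a further entry for compound 2 exists without a single number. The two values of compound 1 and compound 2 lie within the scatter of each other, so they show the same level of inhibition and no difference can be read between them.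

Compound 3, `CN1C(=O)/C(=C(/S)N(C)c2ccc(Cl)cc2)C(=O)c2cc(Cl)ccc21`, has not been measured. It differs from compound 2 in one place: 4-chlorophenyl in place of 3,4-difluorophenyl on an amine nitrogen. Among the measured compounds shown here, no step between measured compounds is recorded for a change of this kind. Since compound 1 and compound 2 sit at the same level despite their different aryl groups on the amine nitrogen, the step is expected to be small, without a direction beyond the scatter, no change at the digits printed from compound 2 to compound 3 (within the scatter). Compound 3 is therefore estimated at 62% in this assay, within 45% to 78%.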

Compound 3, a percentage reported as inhibition, in the whole organism at one dose (the size of the read-out at that dose, not a potency): 47%
Compound 3: the middle estimate sits 15 percentage points above what was measured, and the stated range covers the measured number.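

In this assay, among these compounds, the aryl group on the amine nitrogen now matters, which the earlier compounds did not show: 4-chlorophenyl in place of 3,4-difluorophenyl gives a number 15 percentage points lower from compound 2 to compound 3 (beyond the scatter). The phenyl and 3,4-difluorophenyl groups had left the reading at one level, so a halogen-bearing aryl group at this place is not enough to predict the outcome, and the position is sensitive to which halogen pattern it carries. Nothing available explains this step, so the drop stands as an observation without a cause.

The compounds shown do not separate the identity of the halogen from its place on the ring, a question that 4-fluorophenyl or 3-chlorophenyl on the same amine nitrogen would address. They also leave open how this position would respond to groups without a halogen, such as 4-methoxyphenyl, a pyridyl ring or a benzyl group, and whether the same ranking of aryl groups would hold with a longer chain such as ethyl in place of the methyl on that nitrogen.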